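A Fluorophenyl Thioether Gives Way to a Naphthyl Thioether

The compounds below may be only part of what the source reports. "The series", "measured", "known", "first", "only" and "open" are said of these compounds alone.

Compound 1 `Nc1ccccc1NC(=O)/C=C/c1ccc(CSc2cccc(F)c2)cc1` was tested in a functional assay on A-375 cells (Homo sapiens) for inhibition, read by CCK-8 assay, with a stated time of 72 h, tested at 8 uM (on this read-out higher numbers stand for more inhibition of growth at the one concentration tested and lower numbers for less inhibition of growth), and compound 1 gave 9.08%, the lower of the two values recorded so far. Compound 2 `CCc1ccc(SCc2ccc(C(=O)Nc3ccccc3N)cc2)cc1`, the other measured compound, gave 71.1% in this assay. Compound 3 `Nc1ccccc1NC(=O)/C=C/c1ccc(CSc2cccc3ccccc23)cc1` has not yet been measured. It differs from compound 1 in a single place: naphthalen-1-yl in place of 3-fluorophenyl on a sulfur. Within the data shown here, no measured pair shows this change, so the expected a number 20.9 percentage points higher from compound 1 to compound 3 (beyond the scatter) rests on the two recorded values alone and is estimated as a moderate rise. Compound 3 is therefore estimated to give 30% in this assay, within a range from 5% to 65%.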

Compound 3, percent growth inhibition at one concentration: 36%
The estimate for compound 3 lay 6 percentage points below the measured number; the range from low to high includes it.
By their numbers in this assay, from the lowest: compound 1; then compound 3; then compound 2.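

Naphthalen-1-yl in place of 3-fluorophenyl on the sulfur gives a number 26.9 percentage points higher from compound 1 to compound 3 (beyond the scatter) in this assay. Among these compounds, this is the first measured pair differing in one place, and it shows that the growth inhibition responds to the group on this sulfur and that the two-ring naphthalen-1-yl is accepted there. Nothing measured here explains the rise.

The change removes the fluorine and adds a second ring at once, so the two remain unseparated. From the compounds shown here alone, whether an unsubstituted phenyl, a naphthalen-2-yl or a pyridine ring on the same sulfur would go further also remains open.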